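The source may hold more compounds than are shown below. What is called first, only, known or untested is meant among the compounds shown, and "the series" means these compounds.

Working notes on the series in a functional assay (trachea) with Cavia porcellus as the target; on this read-out lower numbers stand for stronger inhibition and higher numbers for weaker inhibition. Compound 1 (`Oc1nnc(-c2cccnc2)c2ccccc12`) gives 10200 nM. Compound 2 (`CCCCn1nc(-c2cccnc2)c2ccccc2c1=O`), which carries butyl, gives a lower number at 2290 nM. Compound 3 (`CCCCCCCCn1nc(-c2cccnc2)c2ccccc2c1=O`), which carries octyl, gives 21900 nM, the highest of the three numbers and so the weakest inhibition so far.

The next change leads to compound 4 (`O=c1c2ccccc2c(-c2cccnc2)nn1Cc1ccccc1`): phenyl in place of heptyl on a saturated chain carbon bound to an aromatic nitrogen. In words, this is phenyl in place of heptyl on a saturated chain carbon bound to an aromatic nitrogen, and cut one bond further out it reads octyl to benzyl.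

For the measured compounds named here, only one measured step bears on this place: a 9.6-fold higher number from compound 2 to compound 3 (0.98 log units; beyond the scatter), a modest step that lies beyond the scatter. Going by the values given here, no compound with a ring at this place has been measured yet, so the reading across to benzyl is loose. Since compound 4 gives up the octyl chain that took compound 3 upward in a 9.6-fold higher number from compound 2 to compound 3 (0.98 log units; beyond the scatter), part of that rise is expected to be lost. The expected change is a 4.9-fold lower number from compound 3 to compound 4 (0.69 log units; beyond the scatter), toward a lower number, beyond the scatter and estimated to be somewhat smaller than the measured step. For compound 4 the estimated value in this assay is 4500 nM, with an expected range of 1300 nM to 15000 nM.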

Compound 4, half-maximal inhibitory concentration: 2450 nM
Compound 4: middle estimate off by 1.8-fold (0.26 log units), on the high side, and the stated range covers the measured number.
By their numbers in this assay, from the lowest: compounds 2 and 4 (each within the scatter of the next); then compound 1; then compound 3.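

In this assay, the saturated chain carbon bound to an aromatic nitrogen now carries a ring as well as a chain, and the change from octyl to benzyl gives an 8.9-fold lower number from compound 3 to compound 4 (0.95 log units; beyond the scatter), which lies beyond the scatter and takes the number back from the high value seen with octyl. Butyl and benzyl cannot be ranked at this place: the comparison gives a 1.1-fold higher number from compound 2 to compound 4 (0.03 log units; within the scatter), which leaves compound 2 and compound 4 within the scatter of each other, so a six-membered aromatic ring of carbon only and a short open chain read alike here. No measurement at hand accounts for either result.

From the compounds shown here alone, it remains open whether a longer link to the ring, such as phenethyl, or an amine or carboxylic acid at the end of the chain would keep the number near that of compound 4 . Also open, going by these compounds, is where between butyl and octyl the rise sets in, and whether a hexyl chain would already show it.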